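A few compounds are considered here, and "the series" means these few. Any claim that something is new, unique, unknown or untested is made for them only; others in the source may bear on it.

For the measured compounds named here, in a functional assay (Sus scrofa) with sulfonylurea receptors; K-ATP channels (Homo sapiens) as the target (on this read-out higher numbers stand for larger maximal responses and lower numbers for smaller maximal responses), compound 1 `CC(=O)Nc1c(C(O)(C(F)(F)F)C(F)(F)F)ccc2ccccc12` gives 87%, and compound 2 `Cc1cccc(C(=O)Nc2c(C(O)(C(F)(F)F)C(F)(F)F)ccc3ccccc23)c1` gives 97%; the step of a number 10 percentage points higher from compound 1 to compound 2 (within the scatter) lies within the scatter, so the two compounds cannot be told apart on this read-out, and compound 2 stands level with its only neighbour. Compound 3 `O=C(Nc1c(C(O)(C(F)(F)F)C(F)(F)F)ccc2ccccc12)c1ccc(Cl)cc1` differs from compound 2 by 4-chlorophenyl in place of 3-methylphenyl on a carbonyl carbon. Going by the values given here, the one measured step also exchanged the group on this carbonyl carbon and stayed within the scatter, so for compound 3 no step beyond the scatter is expected in this assay. Compound 3 is therefore estimated at 94%, between 80% and 105%, an expected step of a number 3 percentage points lower from compound 2 to compound 3 (within the scatter).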

Compound 3, largest response reached (reported as efficacy), in percent of the reference or control that the assay uses: 99%
Estimate against measurement, compound 3: 5 percentage points below; low and high end bracket the measured number.
By their numbers in this assay, from the lowest: compounds 1, 2 and 3 (each within the scatter of the next, the first and the last beyond it).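

In this assay the exchange of 3-methylphenyl for 4-chlorophenyl on the carbonyl carbon gives a number 2 percentage points higher from compound 2 to compound 3 (within the scatter) and so leaves these two aryl groups indistinguishable. Placing 4-chlorophenyl instead of methyl on that carbon gives a number 12 percentage points higher from compound 1 to compound 3 (beyond the scatter) and is the first step at this position to pass the scatter, though only modestly. Nothing available explains this difference. Still open, as far as these compounds go, is how a longer alkyl chain on this carbonyl carbon would compare with methyl and the two aryl groups. Also open, from the compounds shown here alone, is whether a phenyl ring bearing an amine or a carboxylic acid would keep the response.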